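A few compounds are considered here, and "the series" means these few. Any claim that something is new, unique, unknown or untested is made for them only; others in the source may bear on it.

Measured so far:

- compound 1 `COC(=O)c1ccc(OCCCCOc2ccc(C(=O)CC3CCCC3)c(O)c2C)cc1` — 22%
- compound 2 `Cc1c(OCCCCOc2ccccc2C(=O)O)ccc(C(=O)CC2CCCC2)c1C` — 28%
- compound 3 `CCCC(=O)c1ccc(OCCCCOc2cccc(C(=O)O)c2C)c(C)c1O` — 53%

In an assay on HEK293 cells for positive allosteric modulation of metabotropic glutamate receptor 3 (Rattus norvegicus), read by thallium flux, with a stated time of 2.5 min (a higher number here means a larger maximal response, a lower number a smaller maximal response), compound 1 gives 22%, the lowest of the three numbers. Compound 2 sits nearest, and its value lies within the scatter of compound 1, so the two cannot be ordered. Compound 3 is furthest, and the gap between compound 1 and compound 3 lies beyond the scatter, so compound 3 gives the larger maximal response of those two. Within the data shown here, the two compounds with a free carboxylic acid give the two higher numbers, but with only three compounds this is a loose observation, not a pattern.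

Compound 4 `Cc1c(OCCCCOc2ccc(C(=O)O)cc2Cl)ccc(C(=O)CC2CCCC2)c1O` is not yet measured. It differs from compound 1 in one place: 4-carboxy-2-chlorophenyl in place of 4-(methoxycarbonyl)phenyl on an oxygen on a saturated carbon.

Among the measured compounds shown here, no step between measured compounds that differ in one place is available, so the size of this step has no direct precedent. Given that compound 2 gives 28% and compound 3 gives 53%, both carrying a carboxylic acid, a modest rise is expected for compound 4, though a change within the scatter would not be surprising. The expected step of a number 13 percentage points higher from compound 1 to compound 4 (beyond the scatter) is upward but small. Compound 4 is estimated at 35%, with a range from 18% to 55%.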

Compound 4, largest response reached (reported as percent of maximum), in percent of the reference or control that the assay uses: 27.4%
The estimate for compound 4 lay 7.6 percentage points above the measured number, within the range that was stated.
By their numbers in this assay, from the lowest: compounds 1, 4 and 2 (each within the scatter of the next); then compound 3.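

In this assay, among these compounds, 4-carboxy-2-chlorophenyl in place of 4-(methoxycarbonyl)phenyl on an oxygen on a saturated carbon gives a number 5.4 percentage points higher from compound 1 to compound 4 (within the scatter), the first step that can be read at a single place. At this position, then, the exchange as a whole does not separate the two compounds, and the loose link between a free carboxylic acid and a higher number gains no support here. No measurement available bears on why the step has this size.

The step brings in the carboxylic acid and the chlorine together, and the compounds shown do not give the share of each. Also open, as far as these compounds go, is how a tetrazole or a primary amide would read at this position in this assay, or a bromine on the same ring.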